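Cyclopentyl in place of benzyl on compound 2

A few compounds are considered here, and "the series" means these few. Any claim that something is new, unique, unknown or untested is made for them only; others in the source may bear on it.

Compound 1 `CCC(C)C(NC(=O)NO)C(=O)NCc1ccccc1`: in a functional assay on HeLa cells (Homo sapiens) for inhibition (on this read-out higher numbers stand for weaker inhibition and lower numbers for stronger inhibition), compound 1 gives > 100000 nM, a limit.
Compound 2 `CCC(C)C(NC(=O)n1nnc2ccccc21)C(=O)NCc1ccccc1`: in this assay compound 2 gives >= 100000 nM, a limit.

Compound 2 thus stands at a limit of this assay and has no number. The step that the two limits leave unreadable from compound 1 to compound 2 cannot be read because both ends sit at the limits the limit of > 100000 nM in this assay, at which 1 of the 2 values shown sits, and (the limit of >= 100000 nM in this assay, at which 1 of the 2 values shown sits). Compound 3 `CCC(C)C(NC(=O)n1nnc2ccccc21)C(=O)NC1CCCC1` carries cyclopentyl in place of benzyl on an amide-type nitrogen. Going by the values given here, no measured step is readable, so nothing here sets a size or direction for this change. Compound 3 is expected to stay at the limit, estimated at 100000 nM (range 30000 nM to 300000 nM). The expected step of a number no higher from compound 2 to compound 3 (the limit leaves the size open) is estimated as none beyond the scatter.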

Compound 3, half-maximal inhibitory concentration: 82300 nM
Compound 3: middle estimate off by 1.2-fold (0.08 log units), on the high side, within the range that was stated.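

Compound 3 gives the series its first number rather than a limit in this assay, so the amide-type nitrogen now has a measured reference point: compound 3 gives 82300 nM. Cyclopentyl in place of benzyl gives an at least 1.2-fold lower number from compound 2 to compound 3 (0.08 log units; that floor lies within the scatter), so this change shows no shift beyond the scatter, and its true size stays open. Compound 2 remains a limit: >= 100000 nM.

On these data alone, whether a cyclohexyl group, a longer chain or a carboxylic acid on this nitrogen would move the number remains open. So does whether any such group would bring a step beyond the scatter.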